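A few compounds are considered here, and "the series" means these few. Any claim that something is new, unique, unknown or untested is made for them only; others in the source may bear on it.

Measured in a functional assay on K562 cells (Homo sapiens) for inhibition, read by MTT assay, with a stated time of 48 h; on this read-out higher numbers stand for weaker inhibition and lower numbers for stronger inhibition:
- compound 1 `CC(=O)Nc1nc2ccc(-c3cn([C@@H]4CN[C@H](C(=O)Nc5ccc(Cl)c(C(F)(F)F)c5)C4)nn3)nc2s1`: 10000 nM
- compound 2 `CC(=O)Nc1nc2ccc(-c3cn([C@@H]4CN[C@H](C(=O)Nc5ccc(Cl)cc5Cl)C4)nn3)nc2s1`: 9670 nM
- compound 3 `Nc1nc2ccc(-c3cn([C@@H]4CN[C@H](C(=O)Nc5ccc(Br)cc5)C4)nn3)nc2s1`: 24400 nM

Among these three, compound 3 at 24400 nM has the highest number, and it lies beyond the scatter from both of the others. Compound 4 `CC(=O)Nc1nc2ccc(-c3cn([C@@H]4CN[C@H](C(=O)Nc5ccc(Br)cc5)C4)nn3)nc2s1` differs from compound 3 by a single change: acetyl in place of hydrogen on a nitrogen on an aromatic ring. In words, this is acetyl in place of hydrogen on a nitrogen on an aromatic ring, or amino to acetamido.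

Going by the values given here, no measured step covers this change directly. Among the compounds with values here, the only measured step, a 1.0-fold lower number from compound 1 to compound 2 (0.01 log units; within the scatter), exchanges the group on the amide-type nitrogen between two compounds that both carry acetamido. Compound 3 differs from compound 1 and compound 2 in that group as well as in the amino group, so the gap in their values cannot be assigned to acetyl alone. Even so, compound 4 is expected to fall close to compound 1 at 10000 nM, with a moderate move towards stronger inhibition.

The expected change is a 2.1-fold lower number from compound 3 to compound 4 (0.33 log units; beyond the scatter). For compound 4 the estimated value is 11500 nM, with an expected range from 5000 nM to 26000 nM.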

Compound 4, half-maximal inhibitory concentration: 5020 nM
The estimate for compound 4 lay 2.3-fold (0.36 log units) above the measured number; the range from low to high includes it.
By their numbers in this assay, from the lowest: compounds 4, 2 and 1 (each within the scatter of the next); then compound 3.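

In this assay, acetyl in place of hydrogen on a nitrogen on an aromatic ring, or amino to acetamido, can now be read directly with 4-bromophenyl held on the amide-type nitrogen (a 4.9-fold lower number from compound 3 to compound 4 (0.69 log units; beyond the scatter)). Among the compounds carrying acetamido, exchanging the group on the amide-type nitrogen stays within the scatter (a 1.9-fold lower number from compound 2 to compound 4 (0.28 log units; within the scatter); a 2.0-fold lower number from compound 1 to compound 4 (0.30 log units; within the scatter)), so here the acetyl step is the only single change that lies beyond it. Nothing available accounts for the size of this step.

The compounds shown leave open whether amino to acetamido reads the same with 2,4-dichlorophenyl or 4-chloro-3-(trifluoromethyl)phenyl on the amide-type nitrogen. They also leave open how a different group on the aromatic nitrogen, such as propionyl, methyl or methanesulfonyl, would compare with acetyl.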